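The compounds below may be only part of what the source reports. "The series", "measured", "known", "first", "only" and "open" are said of these compounds alone.

Two compounds have so far been run in a functional assay on HEK293 cells for agonist activity at G-protein coupled receptor 52 (Homo sapiens), read by cAMP accumulation, with a stated time of 15 min; on this read-out higher numbers stand for larger maximal responses and lower numbers for smaller maximal responses. Compound 1 `O=C(NCCO)c1cccc2c1CCN2c1cc(Cc2cc(F)cc(C(F)(F)F)c2)ncn1` reaches 136% in this assay, and compound 2 `O=C(NCCO)c1cccc2c1CCN2c1nncc(Cc2cc(F)cc(C(F)(F)F)c2)c1Cl` reaches 97%. Of these two numbers, compound 1 stands highest. The gap between compound 1 and compound 2 is beyond the usual scatter of repeated measurements. These two compounds differ in more than one place, so nothing more can be read from that pair than the two values themselves.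

Compound 3 `O=C(NCCO)c1cccc2c1CCN2c1cc(Cc2cccc(C(F)(F)F)c2)ncn1` has not yet been measured. It keeps the shared core of compound 1 and differs from it in one spot: hydrogen in place of fluoro on an aromatic carbon. Cut one bond further out, the change reads as 3-fluoro-5-(trifluoromethyl)phenyl becoming 3-(trifluoromethyl)phenyl.

Among the compounds with values here, no pair of measured compounds differs in exactly this way, so there is no measured step to lean on. Removing a single fluorine from an aromatic ring is a small change, and the expectation is for a small step from compound 1 to compound 3 in this assay, if any, of a number 8 percentage points lower from compound 1 to compound 3 (within the scatter), most likely within the scatter. Compound 3 is therefore estimated to reach about 128%, within a range from 100% to 155%.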

Compound 3, largest response reached (Emax), in percent of the reference or control that the assay uses: 127%
Beside the measured number, compound 3's estimate is 1 percentage points above it, within the range that was stated.
By their numbers in this assay, from the lowest: compound 2; then compounds 3 and 1 (each within the scatter of the next).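

Replacing fluoro with hydrogen on this aromatic carbon, a spot meta to a trifluoromethyl group, gives a number 9 percentage points lower from compound 1 to compound 3 (within the scatter) in this assay. Within the data shown here, this is the first single-place comparison, and it shows that at this position, the two compounds cannot be told apart by their largest response: on this one pair, the fluoro makes no measurable difference, and a 3-(trifluoromethyl)phenyl group serves as well as a 3-fluoro-5-(trifluoromethyl)phenyl group on this read-out. Nothing measured here offers an explanation for this result.

The compounds shown leave open whether a chlorine atom, a nitrile or a methoxy group on the same aromatic carbon would also give a response within the scatter of compound 1, and what would follow if hydrogen took the place of the trifluoromethyl group instead. Also open, from the compounds shown here alone, is whether the same fluoro-to-hydrogen change would give a step of similar size on the core of compound 2, as one pair on one core cannot settle that.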